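Swapping an Amide Substituent in a Short-Lived Series

A few compounds are considered here, and "the series" means these few. Any claim that something is new, unique, unknown or untested is made for them only; others in the source may bear on it.

Of the compounds shown here, two from one series have so far been measured in an ADME assay on microsomes from liver (Mus musculus, strain CD-1) for metabolic stability, read by LC-MS, tested at 2 uM; on this read-out higher numbers stand for a longer-lived compound and lower numbers for a shorter-lived compound. Compound 1 `CN1CCCC(NS(=O)(=O)c2ccccc2Nc2cc(-c3ccc4ccn(C)c4c3)c3nccnc3c2)C1` gives 0.483 h in this assay. Compound 2 `Cn1ccc2ccc(-c3cc(Nc4cnccc4C(=O)NCc4cncnc4)cc4nccnc34)cc21` gives 0.4 h in this assay, and the gap between compound 2 and compound 1 lies within the usual scatter of repeated runs, so the two cannot be told apart on this read-out; both are largely gone well inside the first hour.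

Compound 3 `CN1CC(NC(=O)c2ccncc2Nc2cc(-c3ccc4ccn(C)c4c3)c3nccnc3c2)C1` has not yet been measured in this assay. It differs from compound 2 in one place: 1-methylazetidin-3-yl in place of (pyrimidin-5-yl)methyl on an amide-type nitrogen. The amide itself and the rest of the shared core stay as they are.

For the measured compounds named here, no measured pair shows what such a change does here, so there is no step to lean on. Since the two measured compounds sit close together, the step expected from this change, a 1.1-fold higher number from compound 2 to compound 3 (0.05 log units; within the scatter), is none beyond the scatter, in either direction. Compound 3 is therefore estimated at 0.45 h in this assay, with a range from 0.2 h to 1 h.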

Compound 3, half-life: > 1 h
Compound 3: a limit, no number; the forecaster's own chance of this, stated with the estimate: 5%; middle value at least 2.2-fold (0.34 log units) away from the limit.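

This first measured step shows that the group on the amide-type nitrogen does matter for lifetime in this assay, even with the rest of the shared core unchanged. Placing 1-methylazetidin-3-yl there in place of (pyrimidin-5-yl)methyl gives an at least 2.5-fold higher number from compound 2 to compound 3 (0.39 log units; beyond the scatter), the first change in these compounds to move the read-out beyond the scatter. For compound 3, the reading of > 1 h is a limit of the assay and not a number, so the step gives only the smallest size the change can have: the limit of > 1 h in this assay, at which 1 of the 3 values shown sits.

This single swap exchanges a six-membered aromatic ring with 2 hetero atoms for a four-membered non-aromatic ring with 1 hetero atom, so the compounds shown leave open which of these differences goes with the longer half-life. A cyclobutyl group on the same nitrogen, keeping a four-membered ring but carrying no ring nitrogen, or a morpholine ring, would help to separate the ring's size from the presence of its methylated nitrogen.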